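A few compounds are considered here, and "the series" means these few. Any claim that something is new, unique, unknown or untested is made for them only; others in the source may bear on it.

In a functional assay on A549 cells (Homo sapiens) for antiproliferative activity, read by MTT assay, with a stated time of 48 h (on this read-out higher numbers stand for weaker inhibition and lower numbers for stronger inhibition), three compounds built on one shared core give closely matching numbers: compound 1 `CCCCOc1ccc(C(=O)/C=C/c2c(/C=C/c3ccc(OC)cc3)cc(OC)cc2OC)cc1` gives 8.7 ug/mL, compound 2 `COc1ccc(/C=C/c2cc(OC)cc(OC)c2/C=C/C(=O)c2ccc(Br)cc2)cc1` gives 8.3 ug/mL and compound 3 `CCOc1ccc(C(=O)/C=C/c2c(/C=C/c3ccc(OC)cc3)cc(OC)cc2OC)cc1` gives 7.5 ug/mL. Compound 3 thus stands within the scatter of both others. Compound 4 `COc1ccc(/C=C/c2cc(OC)cc(OC)c2/C=C/C(=O)c2ccc(Cl)cc2)cc1` differs from compound 3 as follows: chloro in place of ethoxy on an aromatic carbon. Within the data shown here, two measured steps bear on this change: a 1.0-fold lower number from compound 1 to compound 2 (0.02 log units; within the scatter), with bromo in place of butoxy, and a 1.1-fold lower number from compound 2 to compound 3 (0.04 log units; within the scatter), with ethoxy in place of bromo. Both are small, so no shift beyond the scatter is expected in this assay. The expected step is a 1.1-fold higher number from compound 3 to compound 4 (0.03 log units; within the scatter). Compound 4 is estimated at 8 ug/mL, with an expected range of 4.5 ug/mL to 14 ug/mL.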

Compound 4, half-maximal inhibitory concentration: 6.4 ug/mL
Estimate against measurement, compound 4: 1.3-fold (0.10 log units) above, and the stated range covers the measured number.
By their numbers in this assay, from the lowest: compounds 4, 3, 2 and 1 (each within the scatter of the next).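

In this assay, chloro on this aromatic carbon, para to a large group, stays within the scatter of all three earlier groups: ethoxy (a 1.2-fold lower number from compound 3 to compound 4 (0.07 log units; within the scatter)), bromo (a 1.3-fold lower number from compound 2 to compound 4 (0.11 log units; within the scatter)) and butoxy (a 1.4-fold lower number from compound 1 to compound 4 (0.13 log units; within the scatter)). A second halogen therefore behaves here like the first, and losing the hydrogen-bond acceptor that ethoxy carries brings no change beyond the scatter. So far, these four groups cannot be told apart at this position. Going by these compounds, an amine or a carboxylic acid here remains open, as do changes elsewhere on the shared core. Nothing available explains why these groups give such similar numbers.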